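Methoxybenzyl regiochemistry on a triazole-pyridine series

This account rests on a few compounds, and the source may have more. Where it says the series, first, only, none or still open, it means among the compounds named here.

Measured so far:
compound 1, `COc1cc(Nc2ncccc2-c2nc(Nc3cc(OC)ccc3OC)n[nH]2)cc(OC)c1`, 20%
compound 2, `COc1cccc(CNc2n[nH]c(-c3cccnc3Nc3cc(OC)cc(OC)c3)n2)c1`, 71%

In a functional assay on A-431 cells (Homo sapiens), tested at 0.1 uM (a higher number here means more inhibition at the concentration tested (going by the name of the read-out), a lower number less inhibition), compound 2 stands highest of the two numbers; its nearest neighbour is compound 1, and the step of a number 51 percentage points higher from compound 1 to compound 2 (beyond the scatter), which replaces 2,5-dimethoxyphenyl with 3-methoxybenzyl on a nitrogen on an aromatic ring, is large and beyond the scatter.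

Compound 3, `COc1ccc(CNc2n[nH]c(-c3cccnc3Nc3cc(OC)cc(OC)c3)n2)cc1`, is not yet measured. It differs from compound 2 only in that (4-methoxyphenyl in place of 3-methoxyphenyl on a saturated chain carbon bound to a nitrogen on an aromatic ring). For the measured compounds named here, the one measured step, from compound 1 to compound 2, changes the group on the aromatic nitrogen itself and says nothing about where the methoxy sits on the benzyl ring, so no measured step bears directly on this change. With no guide from the data, the step expected in this assay is a number 9 percentage points lower from compound 2 to compound 3 (within the scatter), that is, none beyond the scatter, with a wide range to cover the lack of precedent. Compound 3 is therefore estimated at 62%, between 35% and 85%.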

Compound 3, a percentage reported as inhibition, at one concentration (the size of the read-out at that concentration, not a potency): 22%
Compound 3: middle estimate off by 40 percentage points, on the high side; the whole stated range lies above it.
By their numbers in this assay, from the lowest: compounds 1 and 3 (each within the scatter of the next); then compound 2.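

In this assay, the position of the methoxy on the benzyl ring carries a large effect: 4-methoxyphenyl in place of 3-methoxyphenyl on a saturated chain carbon bound to a nitrogen on an aromatic ring gives a number 49 percentage points lower from compound 2 to compound 3 (beyond the scatter), even though the two compounds have the same atoms, joined differently. The high reading of compound 2 therefore cannot be credited to a methoxybenzyl group as such, since a number 2 percentage points higher from compound 1 to compound 3 (within the scatter) leaves 4-methoxybenzyl and 2,5-dimethoxyphenyl indistinguishable here, and among these three groups only 3-methoxybenzyl stands apart. Nothing available accounts for this sensitivity to the methoxy position.

The compounds shown leave open whether a plain benzyl group, carrying no methoxy, would read with compound 2 or with compound 3, and so whether the 3-methoxy group raises the reading or the 4-methoxy group lowers it. Also open, from the compounds shown here alone, is whether a longer chain such as phenethyl would keep the level of compound 2, and whether the gap between compound 2 and compound 3 would persist at other concentrations.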